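Trimming Compound 3: Trifluoromethyl Removed From the Pyridine

The source may report more compounds than this note shows. Statements on the series, on what has been measured and on what is new or still open speak of the compounds shown alone.

Compound 1, `FC(F)(F)Oc1ccc(Oc2ccnc(N3CCC(NC(=S)Nc4cccnc4)CC3)c2Cl)cc1Cl`, gives 33 nM.
Compound 2, `FC(F)(F)Oc1ccc(Oc2ccnc(N3CCCC(NC(=S)Nc4cccnc4)C3)c2Cl)c(Cl)c1`, gives 90000 nM.
Compound 3, `FC(F)(F)c1cnc(N2CCC(NC(=S)Nc3cccnc3)CC2)c(Cl)c1`, gives 1100 nM.

These three compounds were measured in an assay on membranes from brain for binding affinity to Lysophosphatidylserine lipase ABHD12 (Mus musculus), read by fluorescence, with a stated time of 20 min; a lower number here means a stronger inhibitor, a higher number a weaker inhibitor. Among the three numbers, compound 3 stands second highest: compound 1 lies well below it and compound 2 well above it, and both gaps lie beyond the usual scatter, so compound 3 is a clearly weaker inhibitor than compound 1 and a clearly stronger one than compound 2.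

Compound 4, `S=C(Nc1cccnc1)NC1CCN(c2ncccc2Cl)CC1`, has not yet been measured. It differs from compound 3 in one place: hydrogen in place of trifluoromethyl on an aromatic carbon. Going by the values given here, no measured pair shows this exact change, so the expected step rests on the wider picture. Compound 1, which carries a large group at that same place, gives 33 nM, while compound 3 with trifluoromethyl there gives 1100 nM; going further to a bare hydrogen is therefore expected to raise the number again, toward a weaker inhibitor, by a step beyond the scatter.

Compound 4 is expected to give about 6000 nM, with a likely range from 1500 nM to 30000 nM. That estimate corresponds to an expected step of a 5.5-fold higher number from compound 3 to compound 4 (0.74 log units; beyond the scatter) in this assay.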

Compound 4, half-maximal inhibitory concentration: > 5000 nM
Compound 4 was reported as a limit; the forecaster's own chance of this, stated with the estimate: 10%; the middle value does not contradict the limit.
By their numbers in this assay, from the lowest: compound 1; then compound 3; then compound 2.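

In this assay, compound 4 gives > 5000 nM, which is a limit of the assay and not an exact number. Even so, the change can be read as a step: hydrogen in place of trifluoromethyl on this aromatic carbon, two atoms from the ring nitrogen, gives an at least 4.5-fold higher number from compound 3 to compound 4 (0.65 log units; beyond the scatter). Going by these compounds alone, none of the earlier compounds formed a pair differing in one place, so this is the first direct sign that the group at this position matters, with all else held the same, and that trifluoromethyl there gives a stronger inhibitor than hydrogen.

On these data alone, the true size of the step stays open, since compound 4 has only a limit. Also open, as far as these compounds go, is how a methyl, a nitrile or a methoxy group on this same carbon would compare with trifluoromethyl and hydrogen.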